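A few compounds are considered here, and "the series" means these few. Any claim that something is new, unique, unknown or untested is made for them only; others in the source may bear on it.

Measured compounds:
Compound 1, `COC(=O)C1(c2ccc(NC(=O)Nc3cccnc3Oc3ccccc3C(C)(C)C)cc2)CC1`, gives 5.1.
Compound 2, `CC(C)(C)c1ccccc1Oc1ncccc1NC(=O)Nc1ccc(C2(CO)CC2)cc1`, gives 4.6.
Compound 3, `CC(C)(C)c1ccccc1Oc1ncccc1NC(=O)Nc1ccc(-c2ccccc2CO)cc1F`, gives 5.5.

In a physicochemical assay for lipophilicity, read by HPLC (a higher number here means a more lipophilic compound, a lower number a more polar compound), compound 2 has the lowest of the three numbers: compound 1 stands a number 0.50 log units lower from compound 1 to compound 2 (beyond the scatter) reversed, that is, a step of a number 0.50 log units lower from compound 1 to compound 2 (beyond the scatter), and compound 3 gives 5.5, further off again, both gaps lying beyond the scatter. The unmeasured compound 4, `CN(C)CC(C)(C)COc1ccc(NC(=O)Nc2cccnc2Oc2ccccc2C(C)(C)C)cc1`, arises from compound 2 by 2-((dimethylamino)methyl)-2-methylpropoxy in place of 1-(hydroxymethyl)cyclopropyl on an aromatic carbon. Among the compounds with values here, only one measured step exists, a number 0.50 log units lower from compound 1 to compound 2 (beyond the scatter), and it concerns a different exchange on a saturated ring carbon, so nothing measured bears directly on the change in hand. The expectation for compound 4 therefore rests on compound 2's 4.6 alone and carries a wide range. He expects compound 4 to give about 4.4 in this assay, between 3.6 and 5.2. That estimate means a step of a number 0.20 log units lower from compound 2 to compound 4 (within the scatter), expected to stay within the usual scatter.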

Compound 4, partition coefficient: 5.1
Estimate against measurement, compound 4: 0.70 log units below; the range from low to high includes it.
By their numbers in this assay, from the lowest: compound 2; then compounds 1 and 4 (each within the scatter of the next); then compound 3.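

Within the data shown here, on the aromatic carbon para to a large group, 2-((dimethylamino)methyl)-2-methylpropoxy in place of 1-(hydroxymethyl)cyclopropyl gives a number 0.50 log units higher from compound 2 to compound 4 (beyond the scatter) in this assay, the first measured exchange of the whole group at this place. Set against 1-(methoxycarbonyl)cyclopropyl, the same group gives no change at the digits printed from compound 1 to compound 4 (within the scatter), so an entering group with no ring and no hydrogen-bond donors reads level with the ester-bearing group and apart from the alcohol-bearing one. Nothing available offers an explanation for these numbers.

As far as these compounds go, the entering group differs from both leaving groups in its ring, its chain and its nitrogen at once, and which of these features carries the step stays open. From the compounds shown here alone, how a carboxylic acid or a primary amine at the end of the same chain would read in this assay also remains open.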